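The source may hold more compounds than are shown below. What is called first, only, known or untested is meant among the compounds shown, and "the series" means these compounds.

In a functional assay for inhibition, with Rattus norvegicus as the target (a higher number here means a weaker inhibitor, a lower number a stronger inhibitor), compound 2 `CC(/N=c1\c(O)c(O)\c1=N/c1ccc(C#N)cc1)C(C)(C)C` gives 520 nM, the lowest of the two numbers in the series, and compound 1 `CC(/N=c1\c(O)c(O)\c1=N/c1ccc(Br)cc1)C(C)(C)C` gives 1260 nM. The gap is a 2.4-fold lower number from compound 1 to compound 2 (0.38 log units; beyond the scatter). Compound 3 `CC(/N=c1\c(O)c(O)\c1=N/c1ccc(-c2ccccc2)cc1)C(C)(C)C` reads > 30000 nM, which is a limit of the assay and not a number. Next comes compound 4 `CC(C)(C)C/N=c1\c(O)c(O)\c1=N/c1ccc(C#N)cc1`, with hydrogen in place of methyl on a saturated chain carbon bound to a double-bonded nitrogen and a saturated chain carbon, or 1,2,2-trimethylpropyl to neopentyl. The measured steps, including an at least 23-fold higher number from compound 1 to compound 3 (1.37 log units; beyond the scatter) and an at least 57-fold higher number from compound 2 to compound 3 (1.76 log units; beyond the scatter), all fall on an aromatic carbon, and none tests this chain. Only a small step is therefore expected, with no firm direction. The estimated step is a 1.2-fold higher number from compound 2 to compound 4 (0.06 log units; within the scatter). For compound 4 the expected value is 600 nM, within an estimated range of 180 nM to 2200 nM.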

Compound 4, half-maximal inhibitory concentration: > 30000 nM
Compound 4 gave a limit, no number; the forecaster's own chance of this, stated with the estimate: 4%; middle value at least 50-fold (1.69 log units) from the limit.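

In this assay, the saturated chain matters as well as the aromatic substituent: with the nitrile held fixed, hydrogen in place of methyl gives an at least 57-fold higher number from compound 2 to compound 4 (1.76 log units; beyond the scatter). The reading for compound 4 is a limit of the assay and not a number, so the full size of this step cannot be read. Compound 3 and compound 4 therefore cannot be ranked against each other: the limit of > 30000 nM in this assay, at which 2 of the 4 values shown sit.

From the compounds shown here alone, it remains open whether ethyl or hydroxymethyl in place of this methyl would retain the read-out of compound 2. The same change with bromo on the aromatic carbon also remains untested in the compounds shown.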